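Changing the group on sulfur in compound 2

The source may hold more compounds than are shown below. What is called first, only, known or untested is meant among the compounds shown, and "the series" means these compounds.

- compound 1 `COc1ccc(-c2nc(CNc3cccc(Cl)c3)nc3ccsc23)cn1`: > 50000 nM, a limit
- compound 2 `COc1ccc(-c2nc(CSc3cccc(Cl)c3)nc3ccsc23)cn1`: > 10000 nM, a limit

In an ADME assay on cells (Homo sapiens) for cytotoxicity, read by resazurin assay, with a stated time of 5 days (on this read-out higher numbers stand for lower toxicity in this test and lower numbers for higher toxicity in this test), neither compound has an exact number, and compound 2 stands only at its limit. Compound 3 `COc1ccc(-c2nc(CSc3ccc(F)cc3F)nc3ccsc23)cn1` differs from it by 2,4-difluorophenyl in place of 3-chlorophenyl on a sulfur. Among the measured compounds shown here, the one measured step, a step that the two limits leave unreadable from compound 1 to compound 2, lies at a different place and offers no size to carry over. With compound 2 at its limit of > 10000 nM as the only anchor, no step beyond the scatter is expected. The estimated change is a step that the limit leaves unreadable from compound 2 to compound 3. For compound 3 the expected value is 20000 nM, with an estimated range from 8000 nM to 60000 nM.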

Compound 3, half-maximal cytotoxic concentration: > 50000 nM
Compound 3: a limit, no number (the forecaster's own chance of this, stated with the estimate: 80%); middle value at least 2.5-fold (0.39 log units) from the limit.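

Compound 1, compound 2 and compound 3 all give only limits in this assay, so the steps among them cannot be read. On these data alone, the concentration at which each compound becomes toxic to the cells remains open.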